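The compounds below may be only part of what the source reports. "The series", "measured", "known", "first", "only" and "open" are said of these compounds alone.

Working notes on the series in a functional assay on HL-60 cells (Homo sapiens) for inhibition, read by MTT assay, with a stated time of 48 h; on this read-out higher numbers stand for weaker inhibition and lower numbers for stronger inhibition. Among the measured compounds shown here, compound 2 `CCCC(CCC)C(=O)OCCCCOC(=O)c1ccc(C(=O)Nc2ccc3c(c2)C(C)(C)CCC3(C)C)cc1` stands at the top of the three numbers measured so far: in this assay compound 2 gives 914000 nM. Its nearest neighbour is compound 1 `C=C(c1ccc(C(=O)OCCCCOC(=O)c2ccc(C(=O)Nc3ccc4c(c3)C(C)(C)CCC4(C)C)cc2)cc1)c1cc2c(cc1C)C(C)(C)CCC2(C)C`, which in this assay gives 25100 nM, a gap beyond the scatter. Compound 3 `C=C(c1ccc(C(=O)OCCCOC(=O)c2ccc(C(=O)Nc3ccc4c(c3)C(C)(C)CCC4(C)C)cc2)cc1)c1cc2c(cc1C)C(C)(C)CCC2(C)C` lies furthest from it; in this assay compound 3 gives 19300 nM, again beyond the scatter. Compound 2 is thus the weakest inhibitor of the three by a clear margin.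

Compound 4 `CCCC(CCC)C(=O)OCCCOC(=O)c1ccc(C(=O)Nc2ccc3c(c2)C(C)(C)CCC3(C)C)cc1` has not yet been measured. It differs from compound 2 in one place: ((1-propylbutyl)carbonyl)oxy in place of (((1-propylbutyl)carbonyl)oxy)methyl on a saturated chain carbon, three bonds along the chain from an oxygen next to a carbonyl group. For the measured compounds named here, no pair of measured compounds differs in exactly this way, so no measured step guides the expectation directly. The change removes one saturated chain carbon and keeps everything else, including the shared core and the hydrogen-bond acceptor count, unchanged, so no step beyond the scatter is expected in either direction.

The expected number for compound 4 in this assay is therefore 850000 nM, with a range from 300000 nM to 2400000 nM, which means an expected step from compound 2 to compound 4 of a 1.1-fold lower number from compound 2 to compound 4 (0.03 log units; within the scatter), within the scatter.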

Compound 4, half-maximal inhibitory concentration: 835000 nM
Compound 4: the middle estimate sits 1.0-fold (0.01 log units) above what was measured; the measured number falls inside the stated range.
By their numbers in this assay, from the lowest: compounds 3 and 1 (each within the scatter of the next); then compounds 4 and 2 (each within the scatter of the next).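

In this assay, among the compounds shown here, the change of ((1-propylbutyl)carbonyl)oxy in place of (((1-propylbutyl)carbonyl)oxy)methyl gives a 1.1-fold lower number from compound 2 to compound 4 (0.04 log units; within the scatter) and is the first step read at this position on a saturated chain carbon. With the 1-propylbutyl end kept, removing one saturated chain carbon therefore produces no change that can be told from the scatter. For the compounds shown here, with the other end group, compound 3 gives 19300 nM and compound 1 gives 25100 nM and these two values also lie within the scatter of each other, so both pairs with this chain difference read the same way, though only the first has a step of its own. No measurement at hand bears on the reason for this flat result.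

The compounds shown cover only these two chain lengths, so it stays open whether a longer chain, or an ether oxygen or an amine set into the chain, would also leave the number in the same place. Going by these compounds, it also stays open whether a carboxylic acid at the chain end would give a number apart from those of the two chain lengths.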